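A few compounds are considered here, and "the series" means these few. Any claim that something is new, unique, unknown or untested is made for them only; others in the source may bear on it.

Within the data shown here, in a functional assay on SK-OV-3 cells (Homo sapiens) for inhibition, read by MTT assay (a higher number here means a weaker inhibitor, a lower number a stronger inhibitor), compound 2 `COc1ccc(/C=C2\c3cc(OC)c(OC)c(OC)c3CC[C@H]2O)cc1N` gives 1870 nM, the lower of the two numbers measured so far, which makes it the stronger inhibitor of the pair. Compound 1 `COc1ccc(/C=C2\c3cc(OC)c(OC)c(OC)c3CC[C@@H]2O)cc1[N+](=O)[O-]`, which carries a nitro group, gives 4640 nM, a gap beyond the usual scatter of repeated measurements. Compound 3 `COc1ccc(/C=C2\c3cc(OC)c(OC)c(OC)c3CC[C@H]2O)cc1[N+](=O)[O-]` has not yet been measured. It differs from compound 2 in one place, with nitro in place of amino on an aromatic carbon. Among the measured compounds shown here, no measured pair shows this change on its own, so the only guide is compound 1, the nitro compound at 4640 nM. A modest move towards weaker inhibition in this assay is therefore expected, a 2.1-fold higher number from compound 2 to compound 3 (0.33 log units; beyond the scatter), and it may lie only just beyond the scatter. For compound 3 the estimated value is 4000 nM, with an expected range of 1500 nM to 11000 nM.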

Compound 3, half-maximal inhibitory concentration: > 10000 nM
Compound 3 was reported as a limit (the forecaster's own chance of this, stated with the estimate: 3%); middle value at least 2.5-fold (0.39 log units) away from the limit.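

Among these compounds, compound 3 gives > 10000 nM in this assay, which is a limit of the assay and not a number, so each step to it has only a lower bound: the limit of > 10000 nM in this assay, at which 1 of the 3 values shown sits. With the drawn configuration held the same, nitro in place of amino on this aromatic carbon, ortho to a methoxy group, brings an at least 5.3-fold higher number from compound 2 to compound 3 (0.72 log units; beyond the scatter), the first clean reading of this change, and it shows that the amino group is favoured over nitro here. Configuration also counts at the saturated ring carbon, with nitro kept in place, as an at least 2.1-fold higher number from compound 1 to compound 3 (0.33 log units; beyond the scatter) is a step that comes from the drawn stereocentre alone: the fact that compounds 1 and 3 differ only in the configuration as drawn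

Still open, going by these compounds, is how far above the limit compound 3 really lies. Also open, on these data alone, is whether a hydroxyl group or an acetamide at this position would behave more like amino or like nitro.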